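A few compounds are considered here, and "the series" means these few. Any claim that something is new, unique, unknown or untested is made for them only; others in the source may bear on it.

Measured so far in this assay:
- compound 1 `Oc1ccccc1/C=N/c1nnc(SCc2nnc(-c3ccccc3Br)o2)s1`: 6780 nM
- compound 2 `Cc1ccccc1-c1nnc(CSc2nnc(/N=C/c3ccccc3O)s2)o1`: 15500 nM
- compound 3 `O=[N+]([O-])c1cccc(-c2nnc(CSc3nnc(/N=C/c4ccccc4O)s3)o2)c1`: 15700 nM

All three compounds share one core and were tested in a functional assay on SMMC-7721 cells (Homo sapiens) for inhibition, read by CCK-8 assay; on this read-out higher numbers stand for weaker inhibition and lower numbers for stronger inhibition. Compound 1 gives the lowest number of the three, so it is the strongest inhibitor here; its nearest neighbour is compound 2, and its furthest is compound 3, both of them beyond the scatter.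

Compound 4 `O=[N+]([O-])c1ccc(-c2nnc(CSc3nnc(/N=C/c4ccccc4O)s3)o2)cc1` has not yet been measured. It differs from compound 1 in one place: 4-nitrophenyl in place of 2-bromophenyl on an aromatic carbon. For the measured compounds named here, two measured steps bear on this change. Both replace the same 2-bromophenyl of compound 1 with another aryl group. The first, a 2.3-fold higher number from compound 1 to compound 3 (0.36 log units; beyond the scatter), puts a nitro group on the phenyl ring, just at a different position. The second, a 2.3-fold higher number from compound 1 to compound 2 (0.36 log units; beyond the scatter), also weakens inhibition by a similar amount. The two alternatives themselves sit close together, a 1.0-fold higher number from compound 2 to compound 3 (0.01 log units; within the scatter), so within these data the replacement of 2-bromophenyl matters more than what replaces it.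

A modest rise in number is therefore expected for compound 4, about a 2.1-fold higher number from compound 1 to compound 4 (0.31 log units; beyond the scatter). The estimate for compound 4 in this assay is 14000 nM, with a range from 6500 nM to 32000 nM.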

Compound 4, half-maximal inhibitory concentration: 16900 nM
For compound 4 the middle estimate is 1.2-fold (0.08 log units) below the measured one, and the stated range covers the measured number.
By their numbers in this assay, from the lowest: compound 1; then compounds 2, 3 and 4 (each within the scatter of the next).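

In this assay, the 4-nitrophenyl of compound 4 cannot be told apart from the 3-nitrophenyl of compound 3, with a 1.1-fold higher number from compound 3 to compound 4 (0.03 log units; within the scatter), so moving the nitro group around the phenyl ring has no readable effect among these two compounds. The same holds for the 2-methylphenyl of compound 2, with a 1.1-fold higher number from compound 2 to compound 4 (0.04 log units; within the scatter), so three different aryl groups on this aromatic carbon now give numbers within the scatter of one another, and a methyl and a nitro group perform alike here. Compound 1 alone stands apart as the strongest inhibitor of the four, and this third replacement of its 2-bromophenyl again weakens inhibition, with a 2.5-fold higher number from compound 1 to compound 4 (0.40 log units; beyond the scatter), while no measurement at hand explains why this group differs from the others.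

For the compounds shown here, with only one bromo compound among the four, the data cannot separate the effect of the bromine itself from the effect of where it sits on the phenyl ring. As far as these compounds go, it also remains open whether a phenyl ring carrying chlorine, fluorine, an amine or a carboxylic acid would match compound 1 or fall with compounds 2, 3 and 4.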